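The source may hold more compounds than are shown below. What is called first, only, known or untested is meant among the compounds shown, and "the series" means these compounds.

Measured compounds:
- compound 1, `O=C(CCCN1CCC(n2c(SCCO)nc3ccccc32)CC1)c1ccc(F)cc1`: 6.9 mg/kg
- compound 2, `O=C(CCCSc1nc2ccccc2n1C1CCN(CCCC(=O)c2ccc(F)cc2)CC1)c1ccc(F)cc1`: 14 mg/kg

Compound 2 has the higher of the two numbers in a functional assay on the whole organism (strain STD-ddY) for inhibition, with Mus musculus as the target, with a stated time of 5 min; a higher number here means that more compound is needed for the effect, a lower number that less compound is needed; the nearest is compound 1, and the step of a 2.0-fold higher number from compound 1 to compound 2 (0.31 log units; beyond the scatter) lies beyond the scatter. Compound 3, `O=C(CCCN1CCC(n2c(SCC(=O)c3ccc(Cl)cc3)nc3ccccc32)CC1)c1ccc(F)cc1`, is not yet measured in this assay. It differs from compound 2 by (4-chlorophenyl)carbonyl in place of 2-((4-fluorophenyl)carbonyl)ethyl on a saturated chain carbon bound to a sulfur. Within the data shown here, no measured step matches this change directly. Among the measured compounds shown here, the only step on hand, a 2.0-fold higher number from compound 1 to compound 2 (0.31 log units; beyond the scatter), was modest and concerned the same saturated chain carbon two bonds from the sulfur, so the group on that side of the sulfur does shift the number, though by little. With the chain shortened and the halogen changed, compound 3 is expected to land between the two measured numbers, giving a 1.4-fold lower number from compound 2 to compound 3 (0.15 log units; within the scatter) toward a lower figure. The estimate for compound 3 is 10 mg/kg, with a range from 4 mg/kg to 25 mg/kg.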

Compound 3, dose for half-maximal effect: 5 mg/kg
Estimate against measurement, compound 3: 2.0-fold (0.30 log units) above, and the stated range covers the measured number.
By their numbers in this assay, from the lowest: compounds 3 and 1 (each within the scatter of the next); then compound 2.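

In this assay, the group on the saturated chain carbon bound to a sulfur can move the number down as well as up: in a 2.8-fold lower number from compound 2 to compound 3 (0.45 log units; beyond the scatter), the change is (4-chlorophenyl)carbonyl in place of 2-((4-fluorophenyl)carbonyl)ethyl. A group carrying an aromatic ring is therefore compatible with a low number here, since (4-chlorophenyl)carbonyl in place of hydroxymethyl gives a 1.4-fold lower number from compound 1 to compound 3 (0.14 log units; within the scatter), a step within the scatter. Nothing available explains either step.

On these data alone, the step away from compound 2 changes both the chain length and the halogen, so the share of each remains open, and (4-fluorophenyl)carbonyl at this place would help to separate them. Also open, as far as these compounds go, is how an amine or a carboxylic acid in place of the hydroxymethyl would behave.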